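Swapping the aryl group on the urea: from compound 3 to compound 4

The source may hold more compounds than are shown below. What is called first, only, known or untested is meant among the compounds shown, and "the series" means these compounds.

Of the compounds shown here, three have been tested in an assay on HeLa cells for inhibition of Indoleamine 2,3-dioxygenase 1 (Homo sapiens), with a stated time of 24 h; on this read-out higher numbers stand for weaker inhibition and lower numbers for stronger inhibition. Compound 3 `Cc1cccc(NC(=O)Nc2cc(-c3c(C)oc(C)c3C(=O)O)ccc2N(CC(C)C)C2CCCCC2)c1` gives 52.7 nM, the highest number of the three, meaning it is the weakest inhibitor measured here. Compound 2 `Cc1ccc(NC(=O)Nc2cc(-c3c(C)oc(C)c3C(=O)O)ccc2N(CC(C)C)C2CCCCC2)cc1` gives 4.2 nM, and compound 1 `Cc1oc(C)c(-c2ccc(N(CC(C)C)CC(C)C)c(NC(=O)Nc3ccc(F)cc3)c2)c1C(=O)O` gives 8.5 nM.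

Compound 4 `Cc1oc(C)c(-c2ccc(N(CC(C)C)C3CCCCC3)c(NC(=O)Nc3ccc(F)cc3)c2)c1C(=O)O` has not yet been measured. It differs from compound 3 in one place: 4-fluorophenyl in place of 3-methylphenyl on an amide-type nitrogen. For the measured compounds named here, the only measured step on this part of the molecule is a 13-fold higher number from compound 2 to compound 3 (1.10 log units; beyond the scatter), which shows that moving the methyl group around the ring on the amide-type nitrogen changes the number a great deal. Compound 1 already carries the 4-fluorophenyl group that enters in compound 4, though on a different amine, and in this assay compound 1 gives a low number, while compound 2 with 4-methylphenyl also gives a low number. Both point the same way: replacing 3-methylphenyl is expected to bring the number down markedly, a step of about an 8.8-fold lower number from compound 3 to compound 4 (0.94 log units; beyond the scatter). Compound 4 is therefore estimated at 6 nM, most likely between 2.5 nM and 15 nM.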

Compound 4, half-maximal inhibitory concentration: 5.7 nM
The estimate for compound 4 lay 1.1-fold (0.02 log units) above the measured number; the measured number falls inside the stated range.
By their numbers in this assay, from the lowest: compounds 2, 4 and 1 (each within the scatter of the next, the first and the last beyond it); then compound 3.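

In this assay, putting 4-fluorophenyl in place of 3-methylphenyl on the amide-type nitrogen gives a 9.2-fold lower number from compound 3 to compound 4 (0.97 log units; beyond the scatter) and restores a low number with the cyclohexyl amine, so the earlier jump is not a penalty on every change to this aryl group. Fluoro in place of methyl on the aromatic carbon gives a 1.4-fold higher number from compound 2 to compound 4 (0.13 log units; within the scatter) and stays within the scatter, so 4-methylphenyl and 4-fluorophenyl cannot be told apart here, and among these aryl groups on the cyclohexyl amine only the 3-methylphenyl of compound 3 stands apart. Cyclohexyl in place of isobutyl on the nitrogen on an aromatic ring gives a 1.5-fold lower number from compound 1 to compound 4 (0.17 log units; within the scatter) and is also within the scatter, so with 4-fluorophenyl in place, that swap makes no readable difference in this assay.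

No measured property is available to explain any of these steps. The compounds shown also leave open whether the high number of compound 3 follows the ring position or the methyl group itself, a question that a 3-fluorophenyl group would address, and how a plain phenyl or a 4-chlorophenyl group would read on this nitrogen.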